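From 3-bromophenyl to 2-hydroxyphenyl: an open step

The source may report more compounds than this note shows. Statements on the series, on what has been measured and on what is new or still open speak of the compounds shown alone.

- compound 1 `CC1CC/C(=N\Nc2ccc(F)cc2)c2ncc(C(=O)O)c(=O)n21`: 1200 nM
- compound 2 `CC1CC/C(=N\Nc2cccc(Cl)c2)c2ncc(C(=O)O)c(=O)n21`: 311000 nM
- compound 3 `CC1CC/C(=N\Nc2cccc(Br)c2)c2ncc(C(=O)O)c(=O)n21`: 6700 nM

In a functional assay (mast cells) for inhibition, with Rattus norvegicus as the target (a lower number here means that less compound is needed, a higher number that more compound is needed for the effect), compound 3 gives 6700 nM, the middle of the three numbers. The steps that reach it are a 5.6-fold higher number from compound 1 to compound 3 (0.75 log units; beyond the scatter) and a 46-fold lower number from compound 2 to compound 3 (1.67 log units; beyond the scatter).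

The next compound, compound 4 `CC1CC/C(=N\Nc2ccccc2O)c2ncc(C(=O)O)c(=O)n21`, keeps the shared core but carries 2-hydroxyphenyl in place of 3-bromophenyl on an amine nitrogen.

All three measured steps changed the group at this same place, and their sizes vary widely. One is modest, as seen above, while a 260-fold higher number from compound 1 to compound 2 (2.41 log units; beyond the scatter) is large. Within the data shown here, none of the measured compounds carries 2-hydroxyphenyl, so the data point in no direction. The best expectation in this assay is therefore no step beyond the scatter, held with low confidence.

The estimated change is a 1.3-fold lower number from compound 3 to compound 4 (0.13 log units; within the scatter).

The expected value for compound 4 is 5000 nM, with an estimated range from 600 nM to 50000 nM.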

Compound 4, half-maximal effective concentration: 208000 nM
The estimate for compound 4 lay 42-fold (1.62 log units) below the measured number, and the stated range ends below it.
By their numbers in this assay, from the lowest: compound 1; then compound 3; then compounds 4 and 2 (each within the scatter of the next).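

Within this assay the change to 2-hydroxyphenyl, the only group here with a hydrogen-bond donor and acceptor, brings a 31-fold higher number from compound 3 to compound 4 (1.49 log units; beyond the scatter) and also a 170-fold higher number from compound 1 to compound 4 (2.24 log units; beyond the scatter) when set against 4-fluorophenyl on the same amine nitrogen. Against 3-chlorophenyl there is a 1.5-fold lower number from compound 2 to compound 4 (0.17 log units; within the scatter) and so no real difference, which means two very different groups give matching numbers, both far from those of compound 1 and compound 3. Nothing measured here explains these large jumps.

From the compounds shown here alone, only one hydroxyphenyl appears, so it remains open whether the result belongs to the hydroxyl itself or to where it sits on the ring. Compounds carrying 4-hydroxyphenyl or 2-methoxyphenyl at this place would help separate those two readings.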